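Phenyl for anilino in the cytotoxicity series

The compounds below may be only part of what the source reports. "The series", "measured", "known", "first", "only" and "open" are said of these compounds alone.

In a functional assay on SEM cells (Homo sapiens) for cytotoxicity, with a stated time of 72 h (a higher number here means that more compound is needed for the effect, a lower number that less compound is needed), compound 1 `C=C[C@@](C)(/C=C/c1ccc(Nc2ccccc2)cc1)CCC=C(C)C` gives > 36600 nM as a limit, not a number. Compound 2 `C=C[C@@](C)(/C=C/c1ccc(Nc2cccc(OC(F)(F)F)c2)cc1)CCC=C(C)C` gives > 36600 nM as a limit too. Compound 3 `C=C[C@@](C)(/C=C/c1ccc(Nc2c(F)cc(F)cc2F)cc1)CCC=C(C)C` gives > 36600 nM as a limit as well. Within the data shown here, the series so far therefore shows the limit of > 36600 nM in this assay, at which 3 of the 3 values shown sit, and offers no measured number.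

Compound 4 `C=C[C@@](C)(/C=C/c1ccc(-c2ccccc2)cc1)CCC=C(C)C` departs from compound 1 by phenyl in place of anilino on an aromatic carbon with phenyl in place of anilino on an aromatic carbon.

Among the measured compounds shown here, two measured steps bear on this change, both altering the anilino group: a step that the two limits leave unreadable from compound 1 to compound 2 and a step that the two limits leave unreadable from compound 1 to compound 3 and neither has a readable size. They give no direction for removing the nitrogen link, so no step beyond the scatter is assumed, and a further reading at the limit is the likeliest outcome.

The expected change is a number no higher from compound 1 to compound 4 (the limit leaves the size open) in this assay on this estimate.

For compound 4 the estimated value is 36600 nM within an expected range of 15000 nM to 60000 nM for a numerical reading.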

Compound 4, half-maximal effective concentration: > 36600 nM
Compound 4 ended at the assay's limit; the forecaster's own chance of this, stated with the estimate: 80%; the middle value lies on the limit itself.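

In this assay compound 4 gives > 36600 nM, a limit and not a number, so the step from compound 1 to compound 4 cannot be read. The compounds shown leave open whether any change on the shared core gives a measured number: the limit of > 36600 nM in this assay, at which 4 of the 4 values shown sit.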